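The source may hold more compounds than are shown below. What is called first, only, known or untested is meant among the compounds shown, and "the series" means these compounds.

Compound 3 `CCOc1ccsc1CN[C@@H]1C[C@H]2C[C@@H]([C@H]1C)C2(C)C` gives 50000 nM in an ADME assay on MDCK cells (Canis lupus familiaris) for cytotoxicity, read by microscopy, with a stated time of 48 h (a lower number here means that less compound is tolerated, a higher number that more compound is tolerated), the highest of the three numbers measured. Compound 1 `C[C@H]1[C@H](NCc2cccs2)C[C@H]2C[C@@H]1C2(C)C` gives 25000 nM, and the step of a 2.0-fold higher number from compound 1 to compound 3 (0.30 log units; within the scatter) stays within the scatter. Going by the values given here, compound 2 `C[C@H]1[C@H](NCc2sccc2-c2ccsc2)C[C@H]2C[C@@H]1C2(C)C` gives 12500 nM, and the step of a 4.0-fold higher number from compound 2 to compound 3 (0.60 log units; beyond the scatter) is the one change that lies beyond the scatter. Compound 4 `C[C@H]1[C@H](NCc2sccc2C2CCCCC2)C[C@H]2C[C@@H]1C2(C)C` differs from compound 3 by cyclohexyl in place of ethoxy on an aromatic carbon. Among the compounds with values here, two measured steps bear on this: a 2.0-fold lower number from compound 1 to compound 2 (0.30 log units; within the scatter) and a 4.0-fold higher number from compound 2 to compound 3 (0.60 log units; beyond the scatter), both pointing to a lower number once a ring replaces a smaller group at that aromatic carbon. Compound 4 is therefore expected to be tolerated less, with an estimated step of a 4.0-fold lower number from compound 3 to compound 4 (0.60 log units; beyond the scatter). The estimate for compound 4 is 12500 nM, within a range from 6000 nM to 30000 nM.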

Compound 4, minimum cytotoxic concentration: 1560 nM
Compound 4: middle estimate off by 8.0-fold (0.90 log units), on the high side, outside the stated range (below it).
By their numbers in this assay, from the lowest: compound 4; then compounds 2, 1 and 3 (each within the scatter of the next, the first and the last beyond it).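

In this assay, cyclohexyl on this aromatic carbon, two ring bonds from the ring sulfur, gives a lower number than each other group shown: ethoxy (a 32-fold lower number from compound 3 to compound 4 (1.51 log units; beyond the scatter)), hydrogen (a 16-fold lower number from compound 1 to compound 4 (1.20 log units; beyond the scatter)) and thiophen-3-yl (an 8.0-fold lower number from compound 2 to compound 4 (0.90 log units; beyond the scatter)). The last step shows that the kind of ring counts here, since one ring replaces another at the same place. From the compounds shown here alone, whether an open chain such as hexyl or a ring holding nitrogen such as piperidinyl would read like cyclohexyl remains open. No measured evidence accounts for these steps.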